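Swapping the ring substituent in the shared core

This account rests on a few compounds, and the source may have more. Where it says the series, first, only, none or still open, it means among the compounds named here.

Within the data shown here, the two measured members share one core. Compound 1 `CC(O)(C(=O)Nc1ccc(C(=O)c2ccccc2F)cc1)C(F)(F)F` carries a 2-fluorophenyl on the carbonyl carbon; in a functional assay (Cavia porcellus) with sulfonylurea receptors; K-ATP channels (Homo sapiens) as the target (a higher number here means a weaker inhibitor, a lower number a stronger inhibitor), compound 1 gives 2300 nM. Among the measured compounds shown here, compound 2 `CC(O)(C(=O)Nc1ccc(C(=O)c2ccc(F)cc2)cc1)C(F)(F)F` carries a 4-fluorophenyl there and gives 14000 nM, the highest of the two numbers recorded; the single recorded step, a 6.1-fold higher number from compound 1 to compound 2 (0.78 log units; beyond the scatter), separates the pair beyond the scatter.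

Compound 3 `Cc1cccc(C(=O)c2ccc(NC(=O)C(C)(O)C(F)(F)F)cc2)c1` is the next candidate. It differs from compound 2 in one place: 3-methylphenyl in place of 4-fluorophenyl on a carbonyl carbon.

For the measured compounds named here, only the step from compound 1 to compound 2 bears on this change, and only loosely. It shows that changing a single ring substituent shifts the number well beyond the scatter, but no methyl group and no 3-substituted phenyl has been measured, so direction cannot be read from it. Compound 3 is expected to land between the two measured values, a step of a 2.3-fold lower number from compound 2 to compound 3 (0.37 log units; beyond the scatter) in this assay. Compound 3 is therefore estimated at 6000 nM, with a range from 1500 nM to 25000 nM.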

Compound 3, half-maximal inhibitory concentration: > 30000 nM
Compound 3: only a limit was reported (the forecaster's own chance of this, stated with the estimate: 10%); at least 5.0-fold (0.69 log units) between middle value and limit.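

Compound 3 gives > 30000 nM in this assay, which is a limit of the assay and not a number: the limit of > 30000 nM in this assay, at which 1 of the 3 values shown sits.

The new steps are an at least 2.1-fold higher number from compound 2 to compound 3 (0.33 log units; beyond the scatter) and an at least 13-fold higher number from compound 1 to compound 3 (1.11 log units; beyond the scatter), so the size of each is a bound rather than a measured distance. The earlier pair showed only that moving the fluorine on the phenyl shifts the number, whereas this result shows that a phenyl without fluorine, carrying a methyl, can give a higher number on the same carbonyl carbon than either fluorophenyl. Across the three compounds, the number rises from 2-fluorophenyl through 4-fluorophenyl to 3-methylphenyl, with every step beyond the scatter, though this order holds only for these three groups.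

The change from 4-fluorophenyl to 3-methylphenyl alters both the substituent and its ring position, so the result cannot assign the rise to either one, and a 3-fluorophenyl or a 4-methylphenyl would separate the two. Going by these compounds, how far compound 3 lies past its limit also stays open, as does the effect of an unsubstituted phenyl or an amine-bearing phenyl at this position.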